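This account rests on a few compounds, and the source may have more. Where it says the series, first, only, none or still open, it means among the compounds named here.

Of the compounds shown here, three sharing one core have been measured in an assay on isolated protein for inhibition of aldehyde dehydrogenase 1A1 (Homo sapiens), read by spectrophotometry, tested at 10 uM; a higher number here means more inhibition at the concentration tested (going by the name of the read-out), a lower number less inhibition. Compound 1, `Cc1cccc(Cn2c(CN3CCN(C(=O)c4ccc([N+](=O)[O-])cc4)CC3)nc3ccccc32)c1`, gives 24.3% in this assay. Among the compounds with values here, compound 3, `Cc1cccc(Cn2c(CN3CCN(C(=O)c4ccc(Br)cc4)CC3)nc3ccccc32)c1`, gives 25.8%, and the one step between measured compounds that differ in a single place, a number 1.5 percentage points higher from compound 1 to compound 3 (within the scatter), changes nothing beyond the scatter. Compound 2, `Cc1ccccc1Cn1c(CN2CCN(C(=O)C3CC3)CC2)nc2ccccc21`, gives 29.1%; its number is the highest of the three, yet its gaps to compound 3 and to compound 1 both fall within the scatter, so the three compounds cannot be told apart on these numbers.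

Compound 4, `O=C(C1CC1)N1CCN(Cc2nc3ccccc3n2Cc2ccc(C(F)(F)F)cc2)CC1`, has not yet been measured in this assay. It differs from compound 2 in one place: 4-(trifluoromethyl)phenyl in place of 2-methylphenyl on a saturated chain carbon bound to an aromatic nitrogen. Within the data shown here, no measured step touches this place; the only step known, from compound 1 to compound 3, changes a group on the amide side of the molecule, and it stayed within the scatter. The three measured numbers all sit close together regardless of which aryl group is present, so a change of group on the benzyl carbon is expected to move the number little. The estimated step of a number 2.1 percentage points lower from compound 2 to compound 4 (within the scatter) is therefore expected to stay within the scatter. Compound 4 is expected to give about 27%, between 12% and 42%.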

Compound 4, a percentage reported as inhibition, at one concentration (the size of the read-out at that concentration, not a potency): 37%
The estimate for compound 4 lay 10 percentage points below the measured number, and the stated range covers the measured number.
By their numbers in this assay, from the lowest: compounds 1, 3, 2 and 4 (each within the scatter of the next, the first and the last beyond it).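

Within the data shown here, exchanging 2-methylphenyl for 4-(trifluoromethyl)phenyl on a saturated chain carbon bound to an aromatic nitrogen gives the first reading at this position, and in this assay it is a number 7.9 percentage points higher from compound 2 to compound 4 (within the scatter). Among these compounds, until now the only step read lay on the amide side of the molecule, so this shows that a step at the benzyl position can also stay within the scatter, even as the group grows from 7 to 10 heavy atoms and takes on three fluorine atoms. Nothing available bears on why the step has this size.

A single step cannot separate the effect of the group on the phenyl ring from that of its place on the ring, since the names 2-methylphenyl and 4-(trifluoromethyl)phenyl differ in both. Going by these compounds, it also remains open whether this position would stay within the scatter with a carboxylic acid or an amine on that phenyl ring, and whether the same exchange would give a similar step in compounds carrying the bromo or nitro amide of compound 3 and compound 1.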